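Swapping the ring-nitrogen substituent on a fused purine-like core

The source may hold more compounds than are shown below. What is called first, only, known or untested is meant among the compounds shown, and "the series" means these compounds.

Measured compounds:
- Compound 1, `FC(F)(F)c1ccc(N2CCN(c3ncnc4[nH]cnc34)CC2)cc1`, in a functional assay on HCT-116 cells (Homo sapiens) for cytotoxicity, read by sulforhodamine B assay, with a stated time of 72 h (a lower number here means a stronger inhibitor, a higher number a weaker inhibitor), gives 5100 nM.
- Compound 2, `Cc1ccc(S(=O)(=O)n2cnc3c(N4CCN(c5ccc(C(F)(F)F)cc5)CC4)ncnc32)cc1`, in this assay gives 4500 nM.
- Compound 3, `FC(F)(F)c1ccc(N2CCN(c3ncnc4c3ncn4C3CCCC3)CC2)cc1`, in this assay gives < 100 nM, which is a limit of the assay and not a number.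

Compound 3 sits at the limit of the assay (the limit of < 100 nM in this assay, at which 1 of the 3 values shown sits), so it is only known to be stronger than the other two, and its true value may lie anywhere beneath that limit. The two steps that reach it, an at least 51-fold lower number from compound 1 to compound 3 (1.70 log units; beyond the scatter) and an at least 45-fold lower number from compound 2 to compound 3 (1.65 log units; beyond the scatter), are both large, while a 1.1-fold lower number from compound 1 to compound 2 (0.05 log units; within the scatter) is not. So far, then, only the cyclopentyl group on the ring nitrogen has given strong inhibition.

Compound 4, `CCOC(=O)Cn1cnc2c(N3CCN(c4ccc(C(F)(F)F)cc4)CC3)ncnc21`, differs from compound 3 by (ethoxycarbonyl)methyl in place of cyclopentyl on an aromatic nitrogen. Going by the values given here, no measured step describes this swap; the closest comparisons are the losses seen when hydrogen or (4-methylphenyl)sulfonyl stands in place of cyclopentyl. Compound 4 is therefore expected to be weaker than compound 3, by a step of roughly an at least 8.0-fold higher number from compound 3 to compound 4 (0.90 log units; beyond the scatter) in this assay, though with wide uncertainty because compound 3 itself is only a limit (the limit of < 100 nM in this assay, at which 1 of the 3 values shown sits). The estimate for compound 4 is 800 nM, between 100 nM and 5000 nM.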

Compound 4, half-maximal inhibitory concentration: 72400 nM
Estimate against measurement, compound 4: 91-fold (1.96 log units) below, and the stated range ends below it.
By their numbers in this assay, from the lowest: compounds 2 and 1 (each within the scatter of the next); then compound 4. At a limit, below all of these: compound 3.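

At this ring nitrogen, a substituent can weaken the compound as well as strengthen it: (ethoxycarbonyl)methyl gives a 14-fold higher number from compound 1 to compound 4 (1.15 log units; beyond the scatter) and a 16-fold higher number from compound 2 to compound 4 (1.21 log units; beyond the scatter) in this assay, so hydrogen and (4-methylphenyl)sulfonyl no longer mark the weak end of the series. Against cyclopentyl the swap gives an at least 720-fold higher number from compound 3 to compound 4 (2.85 log units; beyond the scatter), which shows how widely the group at this one position spreads the numbers while the rest of the molecule stays the same. Compound 3 stands at a limit and not at a number: the limit of < 100 nM in this assay, at which 1 of the 4 values shown sits.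

The two groups differ at once in their ring, their oxygen atoms and their hydrogen-bond acceptors, so the compounds shown cannot say which of these differences matters. Where a carboxylic acid, a simple ethyl or a cyclohexyl at this nitrogen would fall also remains open.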